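A few compounds are considered here, and "the series" means these few. Any claim that something is new, unique, unknown or untested is made for them only; others in the source may bear on it.

Measured in a functional assay on HCT-116 cells (Homo sapiens), read by MTT assay, with a stated time of 72 h; on this read-out lower numbers stand for stronger inhibition and higher numbers for weaker inhibition:
- compound 1 `CN(C)c1ncnc2c1c(-c1ccoc1)cn2[C@@H]1O[C@H](CO)[C@@H](O)[C@H]1O`: > 20000 nM (a limit)
- compound 2 `CN(C)c1ncnc2c1c(-c1ccsc1)cn2[C@@H]1O[C@H](CO)[C@@H](O)[C@H]1O`: > 20000 nM (a limit)
- compound 3 `CN(C)c1ncnc2c1c(-c1cc3ccccc3o1)cn2[C@@H]1O[C@H](CO)[C@@H](O)[C@H]1O`: > 20000 nM (a limit)

Compound 2 stands at > 20000 nM, which is a limit and not a number. The other two compounds give no better footing, as the whole set is summed up by the limit of > 20000 nM in this assay, at which 3 of the 3 values shown sit.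

The next step leads to compound 4 `Cc1ncnc2c1c(-c1ccsc1)cn2[C@@H]1O[C@H](CO)[C@@H](O)[C@H]1O`, which differs from compound 2 as follows: methyl in place of dimethylamino on an aromatic carbon. In words, methyl replaces dimethylamino on an aromatic carbon.

The measured steps all concern the other substituent, not this place. They are a step that the two limits leave unreadable from compound 1 to compound 2, a step that the two limits leave unreadable from compound 1 to compound 3 and a step that the two limits leave unreadable from compound 2 to compound 3. Going by the values given here, none gives a size, and no measured compound carries methyl in place of dimethylamino, so the series offers no direct precedent for this change.

A readable result for compound 4 could only lie on the stronger side of the limit of compound 2 at > 20000 nM, though remaining at the limit is also quite possible. The expected change is an at least 4.0-fold lower number from compound 2 to compound 4 (0.60 log units; beyond the scatter), an estimate that carries wide uncertainty. For compound 4 the estimated value in this assay is 5000 nM, with an expected range of 300 nM to 20000 nM.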

Compound 4, half-maximal inhibitory concentration: 460 nM
For compound 4 the middle estimate is 11-fold (1.04 log units) above the measured one, and the stated range covers the measured number.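

In this assay, with thiophen-3-yl held constant, methyl in place of dimethylamino on the aromatic carbon gives an at least 43-fold lower number from compound 2 to compound 4 (1.63 log units; beyond the scatter); the step starts from a limit, so its true size may be larger. Going by these compounds alone, this shows that the read-out responds strongly to the group at this place on the shared core, something the earlier compounds could not show: the steps among furan-3-yl, thiophen-3-yl and 1-benzofuran-2-yl cannot be read, as each joins two limits. Compound 4 is the only compound shown with a readable number, while the rest of the set stays at a single limit: the limit of > 20000 nM in this assay, at which 3 of the 4 values shown sit.

On these data alone, it remains open whether this step reflects the arrival of methyl or the departure of dimethylamino, a question that a plain amine, a methoxy group or a longer chain such as ethyl at the same carbon could help to settle. As far as these compounds go, it is also open whether methyl gives a readable number alongside furan-3-yl or 1-benzofuran-2-yl, so the step cannot yet be extended beyond the thiophen-3-yl pair.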